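This account rests on a few compounds, and the source may have more. Where it says the series, first, only, none or still open, it means among the compounds named here.

Compounds measured in a functional assay with sulfonylurea receptor 2, Kir6.2 (Homo sapiens) as the target; a lower number here means that less compound is needed, a higher number that more compound is needed for the effect:
compound 1, `CC(C)(C)C(NC(=O)c1ccc(Cl)cc1)N/C(S)=N/c1cccnc1`, gives 2510 nM
compound 2, `CC(C)(C)C(NC(=O)c1ccc(Cl)cc1)N/C(=N/c1cccnc1)NC#N`, gives 6310 nM
compound 3, `CC(C)(C)C(NC(=O)c1ccc(Cl)cc1)N/C(=C/[N+](=O)[O-])Nc1cccnc1`, gives < 100000 nM, which is a limit of the assay and not a number

Among the two numbers shown in this assay, compound 2 sits highest, with compound 1 the nearer of the two: the change a 2.5-fold higher number from compound 1 to compound 2 (0.40 log units; beyond the scatter) is a modest one. For compound 3 the assay reports only a limit, (the limit of < 100000 nM in this assay, at which 1 of the 3 values shown sits), so it gives no number to compare.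

Compound 4, `CC(C)(C)C(NC(=O)c1ccc(Cl)cc1)N/C(=N/c1cccnc1)NS(N)(=O)=O`, differs from compound 2 in one place: sulfamoyl in place of cyano on an amine nitrogen. Within the data shown here, no measured step alters the cyano group itself. Among the measured compounds shown here, the only measured step, a 2.5-fold higher number from compound 1 to compound 2 (0.40 log units; beyond the scatter), changed the substituent on the carbon with a double bond to nitrogen, not the group on the amine nitrogen, and it was modest. Since that is the closest comparison available, the expected step in this assay from compound 2 to compound 4 is also small, in either direction or none beyond the scatter, with a slight lean towards a higher number because the change a 2.5-fold higher number from compound 1 to compound 2 (0.40 log units; beyond the scatter) went that way when a larger group was brought in. The expected step is a 1.3-fold higher number from compound 2 to compound 4 (0.10 log units; within the scatter).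

Compound 4 is therefore estimated at 8000 nM in this assay, within a range of 2500 nM to 25000 nM.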

Compound 4, half-maximal effective concentration: < 100000 nM
Compound 4: no number, only a limit (the forecaster's own chance of this, stated with the estimate: 15%); the middle value lies beyond the limit too.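

In this assay compound 4 gives < 100000 nM, which is a limit of the assay and not a number, so the steps to it from compound 1 and compound 2 cannot be read. The compounds shown leave open how far sulfamoyl in place of cyano actually shifts the number, and whether compound 3 and compound 4 differ at all.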